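Swapping the heteroaryl for an aminophenyl on the sulfonyl

The compounds below may be only part of what the source reports. "The series", "measured", "known", "first", "only" and "open" are said of these compounds alone.

Measured compounds:
compound 1 `Cc1nc(Cl)sc1S(=O)(=O)N1CCC(N2CCC(C)CC2)CC1`: 1.6 nM
compound 2 `CC1CCN(C2CCN(S(=O)(=O)c3ccccc3-c3ccc(C(F)(F)F)cc3)CC2)CC1`: 122 nM
compound 3 `Cc1cc(C)c(S(=O)(=O)N2CCC(N3CCN(C)CC3)CC2)c(C)c1`: 1100 nM

In a functional assay on DLD-1 cells (Homo sapiens) for antiproliferative activity, read by CellTiter-Glo, with a stated time of 72 h (a lower number here means a stronger inhibitor, a higher number a weaker inhibitor), compound 1 gives the lowest number of the three; compound 2 gives a clearly higher number and compound 3 a higher one still, both gaps lying well beyond the scatter. Compound 4 `CC1CCN(C2CCN(S(=O)(=O)c3cccc(N)c3)CC2)CC1` keeps the core of compound 1 and differs in one place: 3-aminophenyl in place of 2-chloro-4-methyl-1,3-thiazol-5-yl on a sulfonyl sulfur. Both measured analogues carrying a six-membered carbon ring on the sulfonyl sulfur, compound 2 and compound 3, return higher numbers than compound 1 in this assay, so the author expects compound 4 to land higher as well, with a step estimated at a 31-fold higher number from compound 1 to compound 4 (1.49 log units; beyond the scatter). For compound 4 the expected value in this assay is 50 nM, within a range of 10 nM to 300 nM.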

Compound 4, half-maximal inhibitory concentration: 3400 nM
Estimate against measurement, compound 4: 68-fold (1.83 log units) below; measured number above the stated range.
By their numbers in this assay, from the lowest: compound 1; then compound 2; then compound 3; then compound 4.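

Exchanging the 2-chloro-4-methyl-1,3-thiazol-5-yl group for 3-aminophenyl on a sulfonyl sulfur, with the rest of the molecule unchanged, gives a 2100-fold higher number from compound 1 to compound 4 (3.33 log units; beyond the scatter) in this assay, which is a large step beyond the scatter. Among the compounds shown here, this is the first direct reading at this position, and it shows that the group on the sulfonyl sulfur alone can shift the number this far. Nothing measured here accounts for the step.

The compounds shown leave open whether the step follows the change of ring or the amine. A plain phenyl, or the same thiazole with an amine in place of the chlorine, would separate the two.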